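Series notes: estimate for compound 3 in the cytotoxicity assay

The compounds below may be only part of what the source reports. "The series", "measured", "known", "first", "only" and "open" are said of these compounds alone.

Measured compounds:
compound 1, `OCC#CCSc1cnc2ccccc2c1SCC#CCBr`: 36.2 ug/mL
compound 2, `CSc1c(SCC#CCO)cnc2ccccc12`: 69.3 ug/mL

In a functional assay on SW707 cells (Homo sapiens) for cytotoxicity, read by sulforhodamine B assay, with a stated time of 72 h (on this read-out lower numbers stand for stronger inhibition and higher numbers for weaker inhibition), compound 1 gives 36.2 ug/mL, the lowest of the two numbers shown; compound 2 gives 69.3 ug/mL, and the step of a 1.9-fold higher number from compound 1 to compound 2 (0.28 log units; within the scatter) stays within the scatter. Compound 3, `C#CC[Se]c1c(SCC#CCO)cnc2ccccc12`, differs from compound 1 by a group of 4 heavy atoms (3 carbon, 1 selenium; no ring) in place of a group of 6 heavy atoms (4 carbon, 1 sulfur, 1 bromine; no ring), on an aromatic carbon. For the measured compounds named here, no measured step touches this aromatic carbon; the one step known, a 1.9-fold higher number from compound 1 to compound 2 (0.28 log units; within the scatter), put a hydrogen atom in place of a group of 4 heavy atoms on a saturated chain carbon bound to a sulfur and stayed within the scatter. No step beyond the scatter is therefore expected: a 1.2-fold higher number from compound 1 to compound 3 (0.09 log units; within the scatter). Compound 3 is estimated at 45 ug/mL, range 20 ug/mL to 100 ug/mL.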

Compound 3, concentration for 50% inhibition: 3.8 ug/mL
For compound 3 the middle estimate is 12-fold (1.07 log units) above the measured one; measured number outside the range, below it.
By their numbers in this assay, from the lowest: compound 3; then compounds 1 and 2 (each within the scatter of the next).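

In this assay this aromatic carbon proves sensitive to its substituent. The group of 4 heavy atoms (3 carbon, 1 selenium) gives a 9.5-fold lower number from compound 1 to compound 3 (0.98 log units; beyond the scatter) and also an 18-fold lower number from compound 2 to compound 3 (1.26 log units; beyond the scatter), whereas compound 1 and compound 2, which carry the two groups it replaces, stay within the scatter of each other. Nothing measured here bears on the origin of these steps. Selenium and the rest of the group change together, so the compounds shown leave open which of them carries the step. Sulfur in place of selenium in the entering group, or an amine on this carbon, would test this.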